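The source may hold more compounds than are shown below. What is called first, only, known or untested is meant among the compounds shown, and "the series" means these compounds.

Of the compounds shown here, three have been measured in a toxicity assay on L02 cells (Homo sapiens) for inhibition, read by CCK-8 assay, with a stated time of 72 h, tested at 20 uM; on this read-out higher numbers stand for more inhibition of growth at the one concentration tested and lower numbers for less inhibition of growth. Compound 1 `CCOC(=O)/C=C1/C(=O)Nc2ccccc21` is the simplest of the set; in this assay compound 1 gives 63.9%. Compound 2 `CC(C)(C)OC(=O)/C=C1/C(=O)N(Cc2ccccc2)c2ccccc21` carries a benzyl group on the amide nitrogen and a tert-butyl ester, and in this assay compound 2 gives 62%. Compound 3 `CC(C)c1ccc2c(c1)/C(=C\C(=O)OC(C)(C)C)C(=O)N2` keeps the free amide and the tert-butyl ester and adds an isopropyl group on the aromatic ring; in this assay compound 3 gives 63.8%. On these three numbers compound 3 sits in the middle, but the gaps to compound 1 and to compound 2 are both within the scatter, so the three compounds cannot be told apart on this read-out.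

Compound 4 `CC(C)(C)OC(=O)/C=C1/C(=O)Nc2ccc(Cl)cc21` has not yet been measured. It differs from compound 3 in one place: chloro in place of isopropyl on an aromatic carbon. Since all three measured compounds give nearly the same number regardless of the ester, the nitrogen substituent or the ring substituent, the step from compound 3 to compound 4 is expected to be small, a number 0.8 percentage points lower from compound 3 to compound 4 (within the scatter), and not beyond the scatter in either direction. For compound 4 the expected value in this assay is therefore 63%, within a range from 50% to 76%.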

Compound 4, percent growth inhibition at one concentration: 63.3%
Beside the measured number, compound 4's estimate is 0.3 percentage points below it, and the stated range covers the measured number.
By their numbers in this assay, from the lowest: compounds 2, 4, 3 and 1 (each within the scatter of the next).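

In this assay, within the data shown here, the exchange of isopropyl for chloro gives the first comparison between compounds that differ in one place, with a number 0.5 percentage points lower from compound 3 to compound 4 (within the scatter) as its result. At this aromatic carbon, meta to a fused ring and para to a fused ring, a group of three carbon atoms and a single chlorine atom therefore cannot be told apart on this read-out, at least with the free amide and the tert-butyl ester held constant. No measurement shown here explains this outcome.

Among these compounds, whether an amine or a carboxylic acid on this same aromatic carbon would give a step beyond the scatter remains open, since isopropyl and chloro are the only two groups compared there. On these data alone, the separate contributions of the ethyl ester in compound 1 and the benzyl group in compound 2 also remain open, as neither compound is linked to another by a change in one place.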